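Chromone acrylamides: a methoxy for a chloro, all at the limit

The compounds below may be only part of what the source reports. "The series", "measured", "known", "first", "only" and "open" are said of these compounds alone.

The measured set, in a functional assay on L02 cells (Homo sapiens) for inhibition, read by MTT assay, with a stated time of 48 h; on this read-out higher numbers stand for weaker inhibition and lower numbers for stronger inhibition:
- compound 1, `O=C(/C=C/c1coc2cc(O)ccc2c1=O)NCc1ccccc1`: > 200000 nM, a limit of the assay, not a number
- compound 2, `COc1ccc2c(=O)c(/C=C/C(=O)Nc3ccccc3Cl)coc2c1`: > 200000 nM, a limit of the assay, not a number
- compound 3, `COc1ccc(NC(=O)/C=C/c2coc3cc(O)ccc3c2=O)cc1`: > 200000 nM, a limit of the assay, not a number

Compound 2 therefore stands only at a limit in this assay, with no number of its own, and the two other values shown stand at the same limit. Within the data shown here, the one step measured between neighbours, a step that the two limits leave unreadable from compound 1 to compound 3, is left unreadable by the two limits, so it gives no size to carry over. What is known is summed up in the limit of > 200000 nM in this assay, at which 3 of the 3 values shown sit.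

Compound 4, `COc1ccc2c(=O)c(/C=C/C(=O)Nc3ccccc3OC)coc2c1`, is not yet measured. It differs from compound 2 by methoxy in place of chloro on an aromatic carbon. Among the measured compounds shown here, no measured step bears on this change, and the whole set so far is silent. Compound 4 is expected to stay at the limit as well, with the step that the limit leaves unreadable from compound 2 to compound 4 expected to be unreadable rather than a real change. The estimate for compound 4 in this assay is 300000 nM, in the range 150000 nM to 1000000 nM.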

Compound 4, half-maximal inhibitory concentration: > 200000 nM
Compound 4: only a limit was reported (the forecaster's own chance of this, stated with the estimate: 80%); the middle value does not contradict the limit.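

In this assay, compound 2 and compound 4 both stand only at a limit, so no step can be read between them. The compounds shown leave open how strong any of them truly is, and whether any change in structure matters: the limit of > 200000 nM in this assay, at which 4 of the 4 values shown sit.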